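Trifluoromethoxy in place of 4-chlorophenoxy on the shared core

This account rests on a few compounds, and the source may have more. Where it says the series, first, only, none or still open, it means among the compounds named here.

Measured so far:
compound 1, `Cc1coc(Cn2nc3ccc(-c4ccc(OC(F)(F)F)cc4)cn3c2=O)n1`, 0.683 h
compound 2, `Cc1nc(Cn2nc3ccc(-c4ccc(Oc5ccc(Cl)cc5)cc4)cn3c2=O)no1`, 6.5 h

The account turns on an ADME assay on microsomes (Rattus norvegicus) for metabolic stability; a higher number here means that the compound lasts longer, a lower number that the compound disappears faster. Of the compounds shown here, two have been measured there. Compound 1 gives 0.683 h, while compound 2 gives 6.5 h, the higher of the two numbers, and the gap between them lies beyond the usual scatter. Within the data shown here, the two compounds differ in more than one place, so their values show only that the compounds stand far apart, not which part of the structure is responsible.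

Compound 3, `Cc1nc(Cn2nc3ccc(-c4ccc(OC(F)(F)F)cc4)cn3c2=O)no1`, has not yet been measured in this assay. It is reached from compound 2 by a single change: trifluoromethyl in place of 4-chlorophenyl on an oxygen on an aromatic ring. Compound 3 thus carries the same trifluoromethoxy as compound 1 while keeping the rest of compound 2 unchanged.

Because compound 1 gives 0.683 h with the same trifluoromethoxy, a lower number is expected for compound 3, a step of a 5.4-fold lower number from compound 2 to compound 3 (0.73 log units; beyond the scatter) that is expected to lie beyond the scatter. Compound 3 is estimated at 1.2 h, with a range from 0.4 h to 3.5 h.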

Compound 3, half-life: 6.05 h
Estimate against measurement, compound 3: 5.0-fold (0.70 log units) below; the measured number lies above the stated range.
By their numbers in this assay, from the lowest: compound 1; then compounds 3 and 2 (each within the scatter of the next).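

In this assay, trifluoromethoxy in place of 4-chlorophenoxy gives a 1.1-fold lower number from compound 2 to compound 3 (0.03 log units; within the scatter) and so leaves the two compounds within the scatter of each other, even though the smaller group has no ring and 4-chlorophenyl leaves with its six-membered aromatic ring. With trifluoromethoxy held the same, 5-methyl-1,2,4-oxadiazol-3-yl in place of 4-methyl-1,3-oxazol-2-yl on the saturated chain carbon bound to an aromatic nitrogen gives an 8.9-fold higher number from compound 1 to compound 3 (0.95 log units; beyond the scatter), a step beyond the scatter, which shows that trifluoromethoxy does not by itself go with a number as low as that of compound 1. The compounds shown offer no independent measurement that would explain either step.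

Going by these compounds, what remains open is whether the step between these two methyl-bearing rings keeps its size when 4-chlorophenoxy stands in place of trifluoromethoxy. On these data alone, it is also open whether the number would stay in the same range with a methyl group, a longer alkyl chain or a cyclohexyl ring on the same oxygen, or with an amine in place of that oxygen.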